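One Methyl Less on a Ring Oxygen of Compound 1

This account rests on a few compounds, and the source may have more. Where it says the series, first, only, none or still open, it means among the compounds named here.

In a functional assay on Huh-7 cells (Homo sapiens), read by fluorescence and BrdU incorporation, with a stated time of 48 h, tested at 25 uM (a lower number here means a stronger effect, a higher number a weaker effect of the compound at the concentration tested), compound 1 `COc1cc(OC)c(C(=O)/C=C/c2ccccc2SC)c(OC)c1` gives 0.3%, and compound 2 `COc1cc(OC)c(C(=O)/C=C/c2ccc(Br)cc2)c(OC)c1` gives 0.2%. For the measured compounds named here, the step of a number 0.1 percentage points lower from compound 1 to compound 2 (within the scatter) lies within the scatter, so the two compounds stand level, and compound 1 sits with the only other measured number. Compound 3 `COc1cc(O)c(C(=O)/C=C/c2ccccc2SC)c(OC)c1` differs from compound 1 in another place: hydrogen in place of methyl on an oxygen on an aromatic ring. No measured step touches an oxygen on the aromatic ring, so nothing shown speaks to the size of this change. The step of a number 0.7 percentage points higher from compound 1 to compound 3 (within the scatter) is expected to be small. Compound 3 is therefore estimated to give 1%, between 0% and 15%.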

Compound 3, a percentage reported as activity, at one concentration (the size of the read-out at that concentration, not a potency): 37%
Beside the measured number, compound 3's estimate is 36 percentage points below it; the whole stated range lies below it.
By their numbers in this assay, from the lowest: compounds 2 and 1 (each within the scatter of the next); then compound 3.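

In this assay, replacing methoxy with hydroxy gives a number 36.7 percentage points higher from compound 1 to compound 3 (beyond the scatter) and so a weaker effect at the concentration tested. This is the first change shown to alter the read-out beyond the usual scatter, and it shows that this methyl on an oxygen on an aromatic ring cannot be removed without loss, unlike the ring swap in a number 0.1 percentage points lower from compound 1 to compound 2 (within the scatter) where the numbers stay level. No measurement available here explains the step.

Going by these compounds, whether a larger group such as ethoxy or an amine at this place would also weaken the effect remains open. So does whether the same methoxy to hydroxy change would do so in compound 2.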